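Cap replacement on the benzylamide hydroxamate series

The compounds below may be only part of what the source reports. "The series", "measured", "known", "first", "only" and "open" are said of these compounds alone.

Compound 2 `CN(C)c1ccc(C(=O)NC(CCCCCC(=O)NO)C(=O)NCc2ccccc2)cc1` and compound 1 `CN(C)c1ccc(C(=O)N[C@H](CCCCCC(=O)NO)C(=O)NCc2ccccc2)cc1` share the same atoms and bonds. In a functional assay on NFF cells (Homo sapiens) for antiproliferative activity (a lower number here means a stronger inhibitor, a higher number a weaker inhibitor), compound 2 gives 870 nM, and compound 1 gives 1000 nM. Compound 2 holds the lowest of the two numbers shown, with compound 1 nearest, and the pair a 1.1-fold lower number from compound 1 to compound 2 (0.06 log units; within the scatter) is within the scatter; it rests on the fact that one of compounds 1 and 2 is drawn with a defined configuration and the other without, at the place where they differ alone. Compound 3 `O=C(CCCCCC(NC(=O)c1cccnc1)C(=O)NCc1ccccc1)NO` differs from compound 2 by pyridin-3-yl in place of 4-(dimethylamino)phenyl on a carbonyl carbon. For the measured compounds named here, no measured step touches the amide cap: the only step available, from compound 1 to compound 2, concerns a stereo drawing, not this ring, so it gives no guide to direction or size in this assay. With nothing to anchor the change, a wide band is appropriate. For compound 3 the expected step is a 1.7-fold higher number from compound 2 to compound 3 (0.24 log units; within the scatter), and the estimate for compound 3 in this assay is 1500 nM, within 400 nM to 6000 nM.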

Compound 3, half-maximal inhibitory concentration: 24000 nM
For compound 3 the middle estimate is 16-fold (1.20 log units) below the measured one; measured number outside the range, above it.
By their numbers in this assay, from the lowest: compounds 2 and 1 (each within the scatter of the next); then compound 3.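

In this assay, for the compounds shown here, the amide cap proves to be a sensitive position: pyridin-3-yl in place of 4-(dimethylamino)phenyl on a carbonyl carbon gives a large step (a 28-fold higher number from compound 2 to compound 3 (1.44 log units; beyond the scatter)), whereas the only earlier step concerned a stereo drawing and stayed within the scatter. The group leaving has 9 heavy atoms and the group entering has 6, while the counts of hydrogen-bond donors and acceptors stay the same, so those counts do not separate compound 2 from compound 3. Nothing in the available evidence bears on the cause of this step.

The compounds shown leave open whether the step follows the ring nitrogen of pyridin-3-yl or the loss of the dimethylamino group, as the two change together here. A plain phenyl on the same carbonyl carbon would separate these two changes.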